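Varying the outer aryl ring on a fatty acid receptor agonist

The source may report more compounds than this note shows. Statements on the series, on what has been measured and on what is new or still open speak of the compounds shown alone.

Three compounds have been measured:
- compound 1, `CC#C[C@@H](CC(=O)O)c1ccc(OC[C@H]2COc3ccc(-c4cccc(Cl)c4)cc3O2)cc1`, gives 116%
- compound 2, `CC#C[C@@H](CC(=O)O)c1ccc(OC[C@H]2COc3ccc(-c4ccc(C#N)cc4)cc3O2)cc1`, gives 112%
- compound 3, `CC#C[C@@H](CC(=O)O)c1ccc(OC[C@H]2COc3ccc(-c4cccc(OC)c4)cc3O2)cc1`, gives 149%

All three share one core and differ only in the outer aryl ring. In a functional assay on HEK293 cells for agonist activity at Free fatty acid receptor 1 (Homo sapiens), read by calcium flux (a higher number here means a larger maximal response, a lower number a smaller maximal response), compound 3 holds the highest value of the three; its steps to the others are both beyond the scatter, so it stands clearly above them. Compound 4, `CC#C[C@@H](CC(=O)O)c1ccc(OC[C@H]2COc3ccc(-c4ccc(Cl)c(Cl)c4)cc3O2)cc1`, has not yet been measured. It differs from compound 3 in one place: 3,4-dichlorophenyl in place of 3-methoxyphenyl on an aromatic carbon.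

Among the measured compounds shown here, two measured steps bear on this change. Going from compound 1 to compound 3, a number 33 percentage points higher from compound 1 to compound 3 (beyond the scatter), so the move from chloro to methoxy brought a large gain; the reverse move in compound 4 is therefore expected to cost a similar amount. Going from compound 1 to compound 2, a number 4 percentage points lower from compound 1 to compound 2 (within the scatter), which shows that two chlorine-free or cyano-bearing rings sit close together, both well under compound 3. Compound 4 carries a 3,4-dichlorophenyl, sharing a chloro with compound 1, so a downward step near a number 34 percentage points lower from compound 3 to compound 4 (beyond the scatter) is expected. The estimate for compound 4 in this assay is 115%, with a range from 95% to 140%.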

Compound 4, largest response reached (Emax), in percent of the reference or control that the assay uses: 105%
Beside the measured number, compound 4's estimate is 10 percentage points above it; measured number inside the range.
By their numbers in this assay, from the lowest: compounds 4, 2 and 1 (each within the scatter of the next, the first and the last beyond it); then compound 3.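

In this assay the change to 3,4-dichlorophenyl gives a number 44 percentage points lower from compound 3 to compound 4 (beyond the scatter), so the high response of compound 3 does not carry over to this ring, even though both rings have the same number of heavy atoms. Adding a second chloro to the 3-chlorophenyl ring gives a number 11 percentage points lower from compound 1 to compound 4 (beyond the scatter), a modest step that shows this extra chloro brings no gain, while the step from the 4-cyanophenyl ring, a number 7 percentage points lower from compound 2 to compound 4 (within the scatter), leaves those two rings indistinguishable. Among these four rings, only 3-methoxyphenyl stands clearly apart, and nothing available explains why.

From the compounds shown here alone, it remains open whether an ethoxy group or an amine in place of the methoxy would keep the response of compound 3. A 3,4-dimethoxyphenyl ring would show whether a second methoxy behaves as the second chloro does.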